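The source may hold more compounds than are shown below. What is called first, only, known or untested is meant among the compounds shown, and "the series" means these compounds.

Measured compounds in an assay on membranes from lung (Cavia porcellus) for binding affinity to cysteinyl leukotriene receptor (Homo sapiens); a lower number here means a stronger inhibitor, a higher number a weaker inhibitor:
compound 1 `CC(CCC(=O)O)Cc1ccc(OCc2ccc3ccccc3n2)cc1`, giving 43 nM
compound 2 `O=C(O)CCCCc1ccc(OCc2ccc3ccccc3n2)cc1`, giving 110 nM

Within the data shown here, compound 2 stands with the higher of the two numbers; the only comparison is compound 1, and the change is a 2.6-fold higher number from compound 1 to compound 2 (0.41 log units; beyond the scatter).

Compound 3 `O=C(O)CC1CCC(c2ccc(OCc3ccc4ccccc4n3)cc2)C1` is unmeasured. It differs from compound 2 as follows: 3-(carboxymethyl)cyclopentyl in place of 4-carboxybutyl on an aromatic carbon. Among the measured compounds shown here, the one measured step concerns the same chain region, where replacing methyl with hydrogen on a saturated chain carbon gave a modest rise in number beyond the scatter. For the measured compounds named here, that step bears only loosely here, since folding the 4-carboxybutyl chain into a 3-(carboxymethyl)cyclopentyl ring is a different kind of change, and no measured pair shows a ring of this type. The expectation for compound 3 is therefore a number near that of compound 2, perhaps modestly lower, with a wide range: a 1.7-fold lower number from compound 2 to compound 3 (0.23 log units; within the scatter). The estimate for compound 3 in this assay is 65 nM, from 20 nM to 220 nM.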

Compound 3, inhibition constant: 22 nM
Compound 3: the middle estimate sits 3.0-fold (0.47 log units) above what was measured, within the range that was stated.
By their numbers in this assay, from the lowest: compounds 3 and 1 (each within the scatter of the next); then compound 2.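

In this assay, the position on the aromatic carbon para to a large group accepts a ring as well as an open chain: 3-(carboxymethyl)cyclopentyl in place of 4-carboxybutyl gives a step beyond the scatter (a 5.0-fold lower number from compound 2 to compound 3 (0.70 log units; beyond the scatter)). Against the methyl-branched chain of compound 1, the ring gives no separation (a 2.0-fold lower number from compound 1 to compound 3 (0.29 log units; within the scatter)), so compound 3 and compound 1 stand within the scatter of each other. Nothing measured accounts for either step.

The compounds shown leave open whether the step from compound 2 belongs to the five-membered ring itself or to the larger count of carbons in the group. A cyclohexyl ring carrying the same carboxymethyl group, or a tetrazole in place of the carboxylic acid, would test how much of this position's tolerance depends on those features.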